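The source may report more compounds than this note shows. Statements on the series, on what has been measured and on what is new or still open speak of the compounds shown alone.

Measured so far:
compound 1, `Cc1nc(-c2ccc(C(F)(F)F)cc2)sc1CNc1ccc(C(=O)O)cc1`: 10%
compound 2, `Cc1nc(-c2ccc(C(F)(F)F)cc2)sc1CNc1ccc(/C=C/C(=O)O)cc1`: 95%

Among the compounds with values here, in a functional assay on CHO cells for agonist activity at Free fatty acid receptor 1 (Homo sapiens), read by a luciferase reporter (on this read-out higher numbers stand for larger maximal responses and lower numbers for smaller maximal responses), compound 2 stands highest of the two numbers; its only neighbour is compound 1, and the step of a number 85 percentage points higher from compound 1 to compound 2 (beyond the scatter) lies beyond the scatter. Compound 3, `Cc1nc(-c2ccc(C(F)(F)F)cc2)sc1CNc1ccc(OCC(=O)O)cc1`, differs from compound 2 as follows: carboxymethoxy in place of 2-carboxyethenyl on an aromatic carbon. Within the data shown here, no measured step covers this exchange of one chain for another; the single step on record, a number 85 percentage points higher from compound 1 to compound 2 (beyond the scatter), concerns the carboxy group against the 2-carboxyethenyl chain and shows that the chain form gives the large response. Carboxymethoxy keeps a chain of the same length, so the number for compound 3 is expected to sit nearer compound 2 than compound 1, though a downward step a number 35 percentage points lower from compound 2 to compound 3 (beyond the scatter) of moderate size is anticipated in this assay given the untested chain. Compound 3 is therefore estimated at 60%, within 30% to 95%.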

Compound 3, largest response reached (reported as percent of maximum), in percent of the reference or control that the assay uses: 100%
Compound 3: the middle estimate sits 40 percentage points below what was measured, and the stated range ends below it.
By their numbers in this assay, from the lowest: compound 1; then compounds 2 and 3 (each within the scatter of the next).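

In this assay, carboxymethoxy in place of 2-carboxyethenyl gives a number 5 percentage points higher from compound 2 to compound 3 (within the scatter), so on this aromatic carbon, para to a large group, the large response does not depend on the second double bond outside aromatic rings, and the chain can carry an oxygen on the aromatic carbon. Against the directly attached carboxy group, the same chain gives a number 90 percentage points higher from compound 1 to compound 3 (beyond the scatter), so a second chain now reproduces the large step, and among these three compounds only compound 1, without a chain, stays low. No supporting evidence bears on why the two chains match.

Open, as far as these compounds go, is whether the saturated 2-carboxyethyl chain, a longer chain such as 3-carboxypropoxy, or an amide in place of the carboxylic acid holds the response here. The largest response alone also leaves open whether compound 2 and compound 3 differ in potency.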